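The source may hold more compounds than are shown below. What is called first, only, known or untested is meant among the compounds shown, and "the series" means these compounds.

Measured compounds:
compound 1, `CCCCCCCCCCCCCCC(N)CO`, in an ADME assay on cells (Splenocyte, Mus musculus, strain BALB/c) for cytotoxicity, read by MTT assay, tested at 10 ug/mL (a higher number here means a stronger effect of the compound at the concentration tested, a lower number a weaker effect), gives 20.2%
compound 2, `CCCCCCCCCCCCCCC(CO)NC(=O)CCCC(=O)O`, gives 14.5%
compound 3, `CCCCCCCCCCCCCCC(CO)N(CC)CC`, gives 12.8%

On the numbers alone compound 3 stands at the low end of the three, yet nothing separates it from the others beyond the usual scatter: the two values of compound 3 and compound 2 sit close together, and the step of a number 7.4 percentage points lower from compound 1 to compound 3 (within the scatter) is also within the scatter. The other change made so far, a number 5.7 percentage points lower from compound 1 to compound 2 (within the scatter), likewise stays within the scatter. Going by the values given here, the three compounds so far differ only at the nitrogen on the shared core, and none of those changes has moved the read-out in this assay by more than the scatter.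

Compound 4, `CCCCCCCCCCCCCCC(CO)NCCCCCC`, is not yet measured. It differs from compound 3 as follows:
hexylamino in place of diethylamino on a saturated chain carbon bound to two saturated chain carbons
The step that bears most directly on this is a number 7.4 percentage points lower from compound 1 to compound 3 (within the scatter), the only one so far that alters the substitution on that nitrogen, and it was within the scatter; the step of a number 5.7 percentage points lower from compound 1 to compound 2 (within the scatter), also at the nitrogen, was as well. Among the compounds with values here, no measured step involves hexylamino, so the expectation rests on these two. Accordingly no step beyond the scatter is expected, with a number 2.2 percentage points higher from compound 3 to compound 4 (within the scatter) as the estimated move in this assay. Compound 4 is therefore expected to give about 15%, with a likely range from 5% to 28%.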

Compound 4, a percentage reported as activity, at one concentration (the size of the read-out at that concentration, not a potency): 14.6%
Compound 4: middle estimate off by 0.4 percentage points, on the high side, within the range that was stated.
By their numbers in this assay, from the lowest: compounds 3, 2, 4 and 1 (each within the scatter of the next).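

Working from this assay, the new result adds a secondary amine carrying one long chain to the set: hexylamino, which has a hydrogen-bond donor that diethylamino lacks, gives a number 1.8 percentage points higher from compound 3 to compound 4 (within the scatter), so neither that donor nor the change from two short chains to one hexyl chain separates the two compounds at this nitrogen. The other two comparisons on the amine nitrogen also stay within the scatter, with hexyl against (3-carboxypropyl)carbonyl giving a number 0.1 percentage points higher from compound 2 to compound 4 (within the scatter) and hexyl against hydrogen giving a number 5.6 percentage points lower from compound 1 to compound 4 (within the scatter), so the free amine, the amide and the diethyl and hexyl amines cannot yet be told apart in this read-out. No measurement at hand offers an explanation for this flat picture.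

Going by these compounds, it remains open whether a much longer chain such as dodecyl, a benzyl group or a quaternary ammonium group on the amine nitrogen would produce a step beyond the scatter. These readings also come from a single concentration, so they leave open whether the four compounds would separate at other concentrations.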